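The source may report more compounds than this note shows. Statements on the series, on what has been measured and on what is new or still open speak of the compounds shown alone.

In an ADME assay (liver) for metabolic stability, with Liver microsome (Homo sapiens) as the target, using microsomes and NADPH, with a stated time of 30 min, tested at 1 uM (a higher number here means faster removal of the compound, a lower number slower removal), the three measured compounds gave:

Compound 1 `CC(C)(C)n1cc(-c2cc(C(O)(C(F)(F)F)C(F)(F)F)cnc2N2CCN(S(=O)(=O)c3ccc(N)nc3)CC2)cn1`: 86 mL.min-1.g-1
Compound 2 `Nc1ccc(S(=O)(=O)N2CCN(c3ncc(C(O)(C(F)(F)F)C(F)(F)F)cc3-c3cccc(F)c3)CC2)cn1`: 25 mL.min-1.g-1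
Compound 3 `NC(=O)c1cccc(-c2cc(C(O)(C(F)(F)F)C(F)(F)F)cnc2N2CCN(S(=O)(=O)c3ccc(N)nc3)CC2)c1`: 17 mL.min-1.g-1

Compound 3 has the lowest number of the three. Its gap to compound 2, a 1.5-fold lower number from compound 2 to compound 3 (0.17 log units; within the scatter), is within the scatter, so the two cannot be ordered, while the step of a 5.1-fold lower number from compound 1 to compound 3 (0.70 log units; beyond the scatter) is beyond it. Compound 4 `Nc1ccc(S(=O)(=O)N2CCN(c3ncc(C(O)(C(F)(F)F)C(F)(F)F)cc3-c3ccc4c(c3)CC(=O)N4)CC2)cn1` differs from compound 3 by a group of 10 heavy atoms (8 carbon, 1 nitrogen, 1 oxygen; one five-membered non-aromatic ring with 1 hetero atom, one six-membered aromatic ring of carbon only) in place of a group of 9 heavy atoms (7 carbon, 1 nitrogen, 1 oxygen; one six-membered aromatic ring of carbon only), on an aromatic carbon. All three measured steps change the group on this same carbon: a 3.4-fold lower number from compound 1 to compound 2 (0.54 log units; beyond the scatter), a 5.1-fold lower number from compound 1 to compound 3 (0.70 log units; beyond the scatter) and a 1.5-fold lower number from compound 2 to compound 3 (0.17 log units; within the scatter). The closest model is the last one, where a carbamoyl replaced fluoro and the number hardly moved; compound 4 keeps a carbonyl and an amide hydrogen, adding one atom in a ring. The step of a 1.1-fold lower number from compound 3 to compound 4 (0.05 log units; within the scatter) is therefore expected to stay within the scatter. Compound 4 is estimated at 15 mL.min-1.g-1, between 7 mL.min-1.g-1 and 35 mL.min-1.g-1.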

Compound 4, intrinsic clearance in microsomes: < 14 mL.min-1.g-1
Compound 4: a limit, no number; the forecaster's own chance of this, stated with the estimate: 5%; at least 1.0-fold (0.02 log units) between middle value and limit.
By their numbers in this assay, from the lowest: compounds 3 and 2 (each within the scatter of the next); then compound 1. At a limit, below all of these: compound 4.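

In this assay compound 4 gives a limit, not a number: the limit of < 14 mL.min-1.g-1 in this assay, at which 1 of the 4 values shown sits. The step of an at least 6.1-fold lower number from compound 1 to compound 4 (0.78 log units; beyond the scatter) clears the scatter, while an at least 1.7-fold lower number from compound 2 to compound 4 (0.25 log units; that floor lies within the scatter) and an at least 1.2-fold lower number from compound 3 to compound 4 (0.08 log units; that floor lies within the scatter) have floors within it, so neither of those two pairs can be ordered. Adding a five-membered non-aromatic ring on this aromatic carbon thus gives no sign of faster removal. From the compounds shown here alone, how far the true number of compound 4 lies past its limit stays open, and so does how a phenyl carrying a carboxylic acid or an amine would compare on this same carbon.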